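Removing the chloro from compound 2 in a cytotoxicity assay

The compounds below may be only part of what the source reports. "The series", "measured", "known", "first", "only" and "open" are said of these compounds alone.

Measured so far:
Compound 1, `Cc1cccc2cc(CN(Cc3ccco3)C(=O)c3ccccc3)c(=O)[nH]c12`: in an ADME assay on MT2 cells (Homo sapiens) for cytotoxicity, read by XTT assay, with a stated time of 4 days (a higher number here means that more compound is tolerated, a lower number that less compound is tolerated), compound 1 gives the limit > 67100 nM.
Compound 2, `Cc1ccc2[nH]c(=O)c(CN(Cc3ccco3)C(=O)c3ccc(Cl)cc3)cc2c1`: in this assay compound 2 gives the limit > 61400 nM.

Both values are limits of the assay and not numbers, so neither compound has a measured half-maximal cytotoxic concentration. Compound 2 stands at the limit of > 61400 nM in this assay, at which 1 of the 2 values shown sits. Compound 1, with its methyl elsewhere on the shared core, stands at the limit of > 67100 nM in this assay, at which 1 of the 2 values shown sits. Among the compounds with values here, no step between two measured compounds can be drawn from two limits.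

Compound 3, `Cc1ccc2[nH]c(=O)c(CN(Cc3ccco3)C(=O)c3ccccc3)cc2c1`, differs from compound 2 by hydrogen in place of chloro on an aromatic carbon. Because both compound 1 and compound 2 sit at the limit of > 67100 nM in this assay, at which 1 of the 2 values shown sits, and (the limit of > 61400 nM in this assay, at which 1 of the 2 values shown sits), the account expects the step that the limit leaves unreadable from compound 2 to compound 3 to be none beyond the scatter. Compound 3 is therefore estimated to give 70000 nM in this assay, with a range from 30000 nM to 160000 nM, and most likely only a limit will be reported again.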

Compound 3, half-maximal cytotoxic concentration: > 67100 nM
Compound 3: no number, only a limit (the forecaster's own chance of this, stated with the estimate: 85%); the middle value does not contradict the limit.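

Compound 2 and compound 3 both give only limits in this assay, so no step can be read for the change from 4-chlorophenyl to phenyl. The compounds shown leave open where the half-maximal cytotoxic concentration of compound 1, compound 2 or compound 3 actually lies.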